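Fluoro in place of acetamido on the ether-linked phenyl

The source may hold more compounds than are shown below. What is called first, only, known or untested is meant among the compounds shown, and "the series" means these compounds.

The series shares the core of compound 1 `Cc1cc(COc2cccc(Cl)c2)nc(-c2ccccn2)n1`, which in a functional assay on cells for antagonist activity at Free fatty acid receptor 1 (Homo sapiens), read by TR-FRET and inositol phosphate accumulation, with a stated time of 2 h (a higher number here means a weaker inhibitor, a lower number a stronger inhibitor), gives 398 nM. Compound 2 `COc1ccccc1OCc1cc(C)nc(-c2ccccn2)n1` gives 2000 nM in this assay. Compound 3 `CC(=O)Nc1ccccc1OCc1cc(C)nc(-c2ccccn2)n1` reaches only a limit of the assay, > 39800 nM, in this assay. Compound 3 thus stands at the weak end of the numbers shown, without a number of its own, and the step of an at least 19-fold higher number from compound 2 to compound 3 (1.29 log units; beyond the scatter) is the one measured step that bears on the change ahead. Compound 4 `Cc1cc(COc2ccccc2F)nc(-c2ccccn2)n1` differs from compound 3 by fluoro in place of acetamido on an aromatic carbon. Removing the acetamido undoes the change seen from compound 2 to compound 3, and compounds 1 and 2 show the numbers reached without it. A large fall in number is expected, an at least 39-fold lower number from compound 3 to compound 4 (1.59 log units; beyond the scatter), in this assay. Compound 4 is therefore estimated at 1000 nM, within 250 nM to 4000 nM.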

Compound 4, half-maximal inhibitory concentration: 398 nM
Beside the measured number, compound 4's estimate is 2.5-fold (0.40 log units) above it; measured number inside the range.
By their numbers in this assay, from the lowest: compounds 1 and 4 (each within the scatter of the next); then compound 2. At a limit, above all of these: compound 3.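

On this aromatic carbon, ortho to a large group, fluoro recovers what acetamido lost in this assay: an at least 100-fold lower number from compound 3 to compound 4 (2.00 log units; beyond the scatter). The position also separates fluoro from methoxy, a 5.0-fold lower number from compound 2 to compound 4 (0.70 log units; beyond the scatter), while 2-fluorophenyl in place of 3-chlorophenyl gives no change at the digits printed from compound 1 to compound 4 (within the scatter). Compound 3 stands at a limit of the assay, so the first step is a bound and not a measured size: the limit of > 39800 nM in this assay, at which 1 of the 4 values shown sits.

Still open, going by these compounds, is whether the loss belongs to the amide hydrogen, the carbonyl or the whole acetamido. An amine or a hydroxyl on this carbon would help separate these.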